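Swapping the Aryl Group on an Aromatic Nitrogen

The source may report more compounds than this note shows. Statements on the series, on what has been measured and on what is new or still open speak of the compounds shown alone.

compound 1 `COc1cc2c(Oc3ccc(NC(=O)c4nn(-c5ccccc5)c(=O)cc4C)cc3F)ccnc2cc1OCCCN1CCN(C)CC1`: 360 nM
compound 2 `COc1cc2c(Oc3ccc(NC(=O)c4nn(-c5ccccc5C)c(=O)cc4C)cc3F)ccnc2cc1OCCCN1CCN(C)CC1`: 3420 nM
compound 3 `COc1cc2c(Oc3ccc(NC(=O)c4nn(-c5cccc(F)c5)c(=O)cc4C)cc3F)ccnc2cc1OCCCN1CCN(C)CC1`: 260 nM

In a functional assay on NCI-H460 cells (Homo sapiens) for inhibition, read by MTT assay, with a stated time of 72 h (a lower number here means a stronger inhibitor, a higher number a weaker inhibitor), compound 3 gives the lowest of the three numbers: compound 1 lies within the scatter of it (a 1.4-fold lower number from compound 1 to compound 3 (0.14 log units; within the scatter)), while compound 2 stands clearly apart (a 13-fold lower number from compound 2 to compound 3 (1.12 log units; beyond the scatter)). Compound 4 `COc1ccc(-n2nc(C(=O)Nc3ccc(Oc4ccnc5cc(OCCCN6CCN(C)CC6)c(OC)cc45)c(F)c3)c(C)cc2=O)cc1` differs from compound 3 by 4-methoxyphenyl in place of 3-fluorophenyl on an aromatic nitrogen. The measured steps that bear on this place are a 1.4-fold lower number from compound 1 to compound 3 (0.14 log units; within the scatter), which stayed within the scatter, and a 9.5-fold higher number from compound 1 to compound 2 (0.98 log units; beyond the scatter), a modest loss. Neither step installs a 4-methoxyphenyl, so the direction is uncertain; the number is expected to stay near that of compound 3, with a step of a 1.7-fold higher number from compound 3 to compound 4 (0.24 log units; within the scatter). Compound 4 is therefore estimated at 450 nM, within a range of 150 nM to 1400 nM.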

Compound 4, half-maximal inhibitory concentration: 3660 nM
For compound 4 the middle estimate is 8.1-fold (0.91 log units) below the measured one; the whole stated range lies below it.
By their numbers in this assay, from the lowest: compounds 3 and 1 (each within the scatter of the next); then compounds 2 and 4 (each within the scatter of the next).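

In this assay the loss seen with the 2-methylphenyl group is no longer a single case: the 4-methoxyphenyl group gives a 10-fold higher number from compound 1 to compound 4 (1.01 log units; beyond the scatter) and also a 14-fold higher number from compound 3 to compound 4 (1.15 log units; beyond the scatter), both large steps. The two losses end level, with a 1.1-fold higher number from compound 2 to compound 4 (0.03 log units; within the scatter), so among these aryl groups only phenyl and 3-fluorophenyl keep the lower numbers. Nothing shown accounts for this difference. On these data alone, whether an amine or a carboxylic acid on this aryl group would bring the same loss stays open, as does whether a longer chain in place of the methoxy group would.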